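The source may hold more compounds than are shown below. What is called first, only, known or untested is meant among the compounds shown, and "the series" means these compounds.

Going by the values given here, compound 2 `COc1ccc(C(=O)/C=C/c2cc(-c3cc(OC)c(OC)c(OC)c3)n[nH]2)cc1OC` stands lowest of the two numbers measured so far: in a functional assay on NCI-H322M cells (Homo sapiens) for cytotoxicity, read by sulforhodamine B assay, with a stated time of 48 h, tested at 10 uM (on this read-out higher numbers stand for a weaker effect at the one concentration tested and lower numbers for a stronger effect), compound 2 gives -96%. Its nearest neighbour is compound 1 `COc1cc(-c2cc(/C=C/C(=O)c3ccc(Cl)c(Cl)c3)[nH]n2)cc(OC)c1OC`, which in this assay gives 59%. Among the compounds with values here, the single measured step, a number 155 percentage points lower from compound 1 to compound 2 (beyond the scatter), is the only one that bears on the next compound. Compound 3 `COc1cc(-c2cc(/C=C/C(=O)c3ccc(F)c(F)c3)[nH]n2)cc(OC)c1OC` carries the change (3,4-difluorophenyl in place of 3,4-dimethoxyphenyl on a carbonyl carbon). This runs the measured step in reverse: a halogenated ring again takes the place of the 3,4-dimethoxyphenyl on the carbonyl carbon, though now with fluorine rather than chlorine. A large upward step is therefore expected in this assay, roughly undoing the drop, because a number 155 percentage points lower from compound 1 to compound 2 (beyond the scatter) was large; how closely 3,4-difluorophenyl tracks 3,4-dichlorophenyl cannot be read from the data, so the range is wide. For compound 3 the expected step is a number 126 percentage points higher from compound 2 to compound 3 (beyond the scatter). The estimate for compound 3 in this assay is 30%, between -50% and 80%.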

Compound 3, a percentage reported as activity, at one concentration (the size of the read-out at that concentration, not a potency): 18%
For compound 3 the middle estimate is 12 percentage points above the measured one; low and high end bracket the measured number.
By their numbers in this assay, from the lowest: compound 2; then compound 3; then compound 1.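

In this assay the change on a carbonyl carbon gives a number 114 percentage points higher from compound 2 to compound 3 (beyond the scatter) and so a second halogenated ring also reads far above the 3,4-dimethoxyphenyl of compound 2, which keeps the lowest number of the three. The two halogenated rings are not interchangeable here, with a number 41 percentage points lower from compound 1 to compound 3 (beyond the scatter) and the choice of halogen therefore moving the read-out on its own, though by less than either step away from 3,4-dimethoxyphenyl. Nothing available on these compounds accounts for this order of the three rings.

The compounds shown leave open whether the low number needs both methoxy groups or follows from one alone. Also open, from the compounds shown here alone, is how an unsubstituted phenyl, or a ring carrying a hydroxyl or a dimethylamino group, would read at this position.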